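Replacing the 3,4-dimethoxyphenyl group of compound 3

This account rests on a few compounds, and the source may have more. Where it says the series, first, only, none or still open, it means among the compounds named here.

Compound 1 `COc1ccc(/C=C/C(=O)c2ccccc2-c2ccc(OC)c(OC)c2)cc1`: 1600 nM
Compound 2 `COc1ccc(/C=C/C(=O)c2ccccc2-c2ccc(OC)c(OC)c2)cc1OC`: 8500 nM
Compound 3 `COc1ccc(OC)c(/C=C/C(=O)c2ccccc2-c2ccc(OC)c(OC)c2)c1`: 4100 nM

In a functional assay on A549 cells (Homo sapiens) for antiproliferative activity, read by sulforhodamine B assay, with a stated time of 48 h (on this read-out lower numbers stand for stronger inhibition and higher numbers for weaker inhibition), compound 3 holds the middle of the three numbers, with a 2.1-fold lower number from compound 2 to compound 3 (0.32 log units; beyond the scatter) and a 2.6-fold higher number from compound 1 to compound 3 (0.41 log units; beyond the scatter). Compound 4 `COc1ccc(OC)c(/C=C/C(=O)c2ccccc2-c2ccc(F)cc2)c1` brings a new change: 4-fluorophenyl in place of 3,4-dimethoxyphenyl on an aromatic carbon. This puts 4-fluorophenyl in place of 3,4-dimethoxyphenyl on an aromatic carbon, ortho to a large group. Going by the values given here, all three measured compounds carry 3,4-dimethoxyphenyl, so no measured step tests this change directly. The closest guides are a 5.3-fold higher number from compound 1 to compound 2 (0.73 log units; beyond the scatter) and the two steps above, all modest. They indicate size only, not direction, so no step beyond the scatter is firmly expected in this assay. The expected step is a 1.5-fold higher number from compound 3 to compound 4 (0.17 log units; within the scatter). For compound 4 the estimated value is 6000 nM, with an expected range of 1800 nM to 20000 nM.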

Compound 4, half-maximal inhibitory concentration: 1100 nM
Beside the measured number, compound 4's estimate is 5.5-fold (0.74 log units) above it; measured number below the stated range.
By their numbers in this assay, from the lowest: compounds 4 and 1 (each within the scatter of the next); then compound 3; then compound 2.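

Going by these compounds alone, compound 4 gives the first reading at this position, since the earlier compounds all carried 3,4-dimethoxyphenyl there: in this assay 4-fluorophenyl on this aromatic carbon, ortho to a large group, comes with a 3.7-fold lower number from compound 3 to compound 4 (0.57 log units; beyond the scatter) and so with stronger inhibition. Inhibition in this assay therefore does not require 3,4-dimethoxyphenyl at this place. Nothing available explains the gain. Open, going by these compounds, is whether the fluorine matters or only the loss of the methoxy groups, which an unsubstituted phenyl or 4-aminophenyl here would separate. Also open, on these data alone, is whether the gain carries over to the 4-methoxyphenyl series of compound 1.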